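The source may hold more compounds than are shown below. What is called first, only, known or untested is meant among the compounds shown, and "the series" means these compounds.

In a functional assay on MCF7 cells (Homo sapiens) for cytotoxicity, read by MTT assay, with a stated time of 48 h (a higher number here means a weaker inhibitor, a lower number a stronger inhibitor), compound 3 `CCc1ccc(NC(=O)N(Cc2cc(OC)c(OC)c(OC)c2)n2cnnc2)cc1` gives 24800 nM. Compound 2 `COc1ccc(CN(C(=O)Nc2ccc(F)c(Cl)c2)n2cnnc2)cc1OC` gives 30100 nM, a value within the usual scatter of that of compound 3, so the two cannot be told apart. Compound 1 `COc1ccc(CN(C(=O)Nc2ccc(Cl)cc2)n2cnnc2)cc1OC` gives > 50000 nM, which is the limit of > 50000 nM in this assay, at which 1 of the 3 values shown sits, and not a number.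

Compound 4 `CCc1ccc(NC(=O)N(Cc2ccc(OC)c(OC)c2)n2cnnc2)cc1` differs from compound 3 by hydrogen in place of methoxy on an aromatic carbon. Within the data shown here, the only measured step, an at least 1.6-fold lower number from compound 1 to compound 2 (0.22 log units; that floor lies within the scatter), alters the other aromatic ring, the one attached to the amide-type nitrogen, and leaves the methoxy groups untouched, so no measured step bears on this change. Among the measured compounds shown here, with no comparable step, the expected step is a 1.2-fold higher number from compound 3 to compound 4 (0.08 log units; within the scatter), nothing beyond the scatter. Compound 4 is therefore estimated at about 30000 nM, with a range from 10000 nM to 100000 nM.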

Compound 4, half-maximal inhibitory concentration: > 50000 nM
Compound 4: a limit, no number (the forecaster's own chance of this, stated with the estimate: 30%); middle value at least 1.6-fold (0.22 log units) from the limit.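

In this assay compound 4 carries a limit and not a number: the limit of > 50000 nM in this assay, at which 2 of the 4 values shown sit. Hydrogen in place of methoxy, the first change measured on this ring, gives an at least 2.0-fold higher number from compound 3 to compound 4 (0.30 log units; that floor lies within the scatter), while 4-ethylphenyl in place of 3-chloro-4-fluorophenyl gives an at least 1.6-fold higher number from compound 2 to compound 4 (0.22 log units; that floor lies within the scatter), so both are only floors and neither shows a real loss beyond the scatter. The step between compound 1 and compound 4 joins two limits and cannot be read.

Still open, from the compounds shown here alone, is what number compound 4 would give without the limit. Also open, going by these compounds, is whether a hydroxy group or a fluorine atom on this aromatic carbon would behave like the methoxy of compound 3 or the hydrogen of compound 4.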